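This account rests on a few compounds, and the source may have more. Where it says the series, first, only, none or still open, it means among the compounds named here.

Working notes on the series, continued from compound 2.

Compound 2 `N#Cc1ccc(-c2ccc(CO[C@@H]3COc4nc([N+](=O)[O-])cn4C3)cc2)cc1` gives 95% in an ADME assay on microsomes from liver (Homo sapiens) for metabolic stability, read by LC-MS, with a stated time of 1 h (on this read-out lower numbers stand for a less stable compound and higher numbers for a more stable compound), the higher of the two numbers recorded so far. Compound 1 `O=[N+]([O-])c1cn2c(n1)OC[C@@H](OCc1ccc(-c3ccc(C(F)(F)F)cc3)cc1)C2` gives 60% in this assay. Within the data shown here, the one recorded step is a number 35 percentage points higher from compound 1 to compound 2 (beyond the scatter). It concerns the aromatic carbon para to the large group, and it moved the read-out far beyond the scatter. Compound 3 `O=[N+]([O-])c1cn2c(n1)OC[C@@H](OCc1ccc(-c3ccc(Oc4ccccc4)cc3)cc1)C2` alters that same carbon again: phenoxy in place of cyano on an aromatic carbon. Among the measured compounds shown here, no measured pair contains phenoxy, so the only guide is that exchanging the group at this position has already produced a large shift. With compound 2 near the top of the scale, the room upward is small, so the expected step of a number 45 percentage points lower from compound 2 to compound 3 (beyond the scatter) is a decrease beyond the scatter. For compound 3 the expected value in this assay is estimated at 50%, within 20% to 85%.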

Compound 3, percent of the compound remaining: 22%
Estimate against measurement, compound 3: 28 percentage points above; measured number inside the range.
By their numbers in this assay, from the lowest: compound 3; then compound 1; then compound 2.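

In this assay, the aromatic carbon para to a large group can move the read-out down as well as up: phenoxy gives a number 73 percentage points lower from compound 2 to compound 3 (beyond the scatter) and a number 38 percentage points lower from compound 1 to compound 3 (beyond the scatter). The three groups at this carbon now fall in a clear order, with phenoxy lowest, trifluoromethyl in the middle and cyano highest, so the position is sensitive to substitution in both directions from trifluoromethyl. Nothing available explains why these groups differ.

Going by these compounds, it remains open whether the low number goes with the added aromatic ring or with the oxygen that joins it to the biphenyl-like part of the molecule, and a plain phenyl or a benzyl group at this carbon would separate the two. On these data alone, how an amine or a carboxylic acid at the same carbon would read also remains open.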